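Toward compound 3: a carbonyl-bearing analogue in sigma-1 binding

This account rests on a few compounds, and the source may have more. Where it says the series, first, only, none or still open, it means among the compounds named here.

Measured so far:
compound 1, `[O-][S+](CCNC1CCN(Cc2ccc(F)cc2)CC1)C(c1ccc(F)cc1)c1ccc(F)cc1`, 26.5 nM;
compound 2, `O=C(c1ccccc1F)N1CCC(NCCSC(c2ccc(F)cc2)c2ccc(F)cc2)CC1`, 3.57 nM.

Of the compounds shown here, two have been tested in an assay on membranes from Cortex for displacement of a labelled ligand from Sigma non-opioid intracellular receptor 1 (Cavia porcellus), read by scintillation counting, with a stated time of 120 min; on this read-out lower numbers stand for stronger inhibition and higher numbers for weaker inhibition. Compound 1 gives 26.5 nM, which is the higher of the two numbers, while compound 2 gives 3.57 nM, a clearly lower number and therefore stronger binding; the gap between them lies well beyond the scatter of repeat measurements. Among the measured compounds shown here, no single-point step between these two has been worked out, so only the two values themselves can be read from this pair.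

The next compound, compound 3, `O=C(c1ccccc1F)N1CCC(NCC[S+]([O-])C(c2ccc(F)cc2)c2ccc(F)cc2)CC1`, has not yet been measured. It arises from compound 1 by one change: (2-fluorophenyl)carbonyl in place of 4-fluorobenzyl on an amine nitrogen in a ring. The ring in question is the six-membered non-aromatic ring with one nitrogen that forms part of the shared core of compound 1.

For the measured compounds named here, with only two measured compounds and no mapped step, the expectation rests on the fact that compound 2 carries the same entering group and sits at 3.57 nM. Compound 3 is therefore expected to move toward a lower number, by a step of a 2.7-fold lower number from compound 1 to compound 3 (0.42 log units; beyond the scatter). The estimate for compound 3 in this assay is 10 nM, within a range from 3 nM to 35 nM.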

Compound 3, inhibition constant: 1310 nM
Compound 3: the middle estimate sits 130-fold (2.12 log units) below what was measured; the whole stated range lies below it.
By their numbers in this assay, from the lowest: compound 2; then compound 1; then compound 3.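

Changing the group on the ring nitrogen of the shared core has a large effect in this assay: (2-fluorophenyl)carbonyl in place of 4-fluorobenzyl gives a 49-fold higher number from compound 1 to compound 3 (1.69 log units; beyond the scatter). The two groups are close in what can be counted, since both hold one six-membered aromatic ring of carbon only and the entering group adds just one heavy atom, a carbonyl oxygen that counts as a hydrogen-bond acceptor, so a small swap at this position can shift the number strongly. The group does not bring a high number in every compound shown, as compound 2, which carries the same (2-fluorophenyl)carbonyl group, gives 3.57 nM, while compound 3 gives 1310 nM.

Nothing measured here explains why the number rises at this position. The carbonyl and the changed fluorine placement arrive together, so these compounds leave open which of them carries the step; a 2-fluorobenzyl group on the same nitrogen, which keeps the fluorine placement of the entering group without the carbonyl, would separate the two.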